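Adding a phenyl to compound 3: what to expect

The compounds below may be only part of what the source reports. "The series", "measured", "known", "first", "only" and "open" are said of these compounds alone.

Measured compounds so far:
compound 1 `CN(C)CCCCCSC1=Nc2ccccc2C(CC(=O)NCc2ccccc2)N1c1ccc(-c2ccccc2)cc1`: 1760 nM
compound 2 `O=C(CC1c2ccccc2N=C(SCCCCCN2CCCC2)N1c1ccc(-c2ccc(F)cc2)cc1)NCc1ccccc1`: 5100 nM
compound 3 `O=C(CC1c2ccccc2N=C(SCCCCCN2CCCC2)N1c1ccccc1)NCc1ccccc1`: 6190 nM

In an assay on cells for inhibition of Voltage-dependent T-type calcium channel subunit alpha-1I (Homo sapiens), read by patch clamp (a lower number here means a stronger inhibitor, a higher number a weaker inhibitor), compound 3 has the highest number of the three, but it sits within the scatter of compound 2 and only clearly apart from compound 1. Compound 4 `O=C(CC1c2ccccc2N=C(SCCCCCN2CCCC2)N1c1ccc(-c2ccccc2)cc1)NCc1ccccc1` differs from compound 3 in one place: phenyl in place of hydrogen on an aromatic carbon. Among the measured compounds shown here, the one measured step that touches this place is a 1.2-fold higher number from compound 2 to compound 3 (0.08 log units; within the scatter), where the loss of a closely related ring changed almost nothing. Compound 4 carries the same phenyl as compound 1 but differs from it elsewhere, so the value of compound 1, 1760 nM, can only hint at a lower number. The expected step of a 1.8-fold lower number from compound 3 to compound 4 (0.25 log units; within the scatter) is therefore small, perhaps a modestly lower number. Compound 4 is estimated at 3500 nM, in a range from 1200 nM to 10000 nM.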

Compound 4, half-maximal inhibitory concentration: 810 nM
Compound 4: the middle estimate sits 4.3-fold (0.64 log units) above what was measured, outside the stated range (below it).
By their numbers in this assay, from the lowest: compound 4; then compound 1; then compounds 2 and 3 (each within the scatter of the next).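

In this assay the phenyl brings a 7.6-fold lower number from compound 3 to compound 4 (0.88 log units; beyond the scatter) even though the 4-fluorophenyl of compound 2 sat within the scatter of the hydrogen of compound 3. A single fluoro on the added ring therefore separates these outcomes, since its loss gives a 6.3-fold lower number from compound 2 to compound 4 (0.80 log units; beyond the scatter) at this position. With the 4-phenylphenyl kept, the amine also counts: pyrrolidin-1-yl in place of dimethylamino gives a 2.2-fold lower number from compound 1 to compound 4 (0.34 log units; beyond the scatter) on the chain. Nothing at hand explains these steps. As far as these compounds go, whether a chloro or methoxy on the added ring would act like fluoro or like hydrogen stays open, as does a piperidine on the chain.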